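From 4-fluorophenyl to (4-methylphenyl)amino on the shared core

The compounds below may be only part of what the source reports. "The series", "measured", "known", "first", "only" and "open" are said of these compounds alone.

Going by the values given here, compound 1 `COc1cc(C(=O)c2sc3ccccc3c2-c2ccc(F)cc2)cc(OC)c1OC` is the only member of this small set with a definite number: in a functional assay on Jurkat cells (Homo sapiens) for antiproliferative activity, read by MTT assay, with a stated time of 72 h (a lower number here means a stronger inhibitor, a higher number a weaker inhibitor), compound 1 gives 2300 nM. Compound 2 `COc1ccc(OC)c(-c2c(C(=O)c3cc(OC)c(OC)c(OC)c3)sc3ccccc23)c1` reaches only a limit of this assay, giving > 10000 nM. Among the compounds with values here, the single measured step, an at least 4.3-fold higher number from compound 1 to compound 2 (0.63 log units; beyond the scatter), therefore rests on (the limit of > 10000 nM in this assay, at which 1 of the 2 values shown sits).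

Compound 3 `COc1cc(C(=O)c2sc3ccccc3c2Nc2ccc(C)cc2)cc(OC)c1OC` differs from compound 1 by (4-methylphenyl)amino in place of 4-fluorophenyl on an aromatic carbon. Within the data shown here, no measured step concerns this particular change; the only step known, an at least 4.3-fold higher number from compound 1 to compound 2 (0.63 log units; beyond the scatter), describes a different replacement on the aromatic carbon and shows merely that altering the group there can cost activity. The account therefore expects for compound 3 in this assay a shift not clearly beyond the scatter, with wide uncertainty. Compound 3 is estimated at 3000 nM, within 800 nM to 12000 nM. The expected step is a 1.3-fold higher number from compound 1 to compound 3 (0.12 log units; within the scatter).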

Compound 3, half-maximal inhibitory concentration: 1700 nM
Compound 3: the middle estimate sits 1.8-fold (0.25 log units) above what was measured, and the stated range covers the measured number.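

In this assay, (4-methylphenyl)amino in place of 4-fluorophenyl gives a 1.4-fold lower number from compound 1 to compound 3 (0.13 log units; within the scatter), so this aromatic carbon can carry an amino-linked ring as well as a directly attached one without a change beyond the scatter. The other comparison gives an at least 5.8-fold lower number from compound 2 to compound 3 (0.76 log units; beyond the scatter), which shows that the earlier loss does not follow from every replacement of 4-fluorophenyl at this position. Compound 2 gives > 10000 nM, a limit and not a number, so this step has a bound and no exact size: the limit of > 10000 nM in this assay, at which 1 of the 3 values shown sits.

Open, on these data alone, is whether the amino hydrogen itself matters, a question that an N-methyl amine at this carbon would address. Also open, as far as these compounds go, is how the number would respond to a smaller group here, such as a plain amine or a methoxy group.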